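Cyclopropane aryl swap on the biphenyl amide series

This account rests on a few compounds, and the source may have more. Where it says the series, first, only, none or still open, it means among the compounds named here.

Compound 1 `CC(C)(C)[C@H](N)CN(C(=O)[C@@H]1C[C@H]1c1ccccc1)c1ccc(-c2ccccc2)cc1` gives 11 nM in a functional assay for agonist activity at G protein-coupled receptor 88 (Homo sapiens), read by HTRF and cAMP accumulation; a higher number here means that more compound is needed for the effect, a lower number that less compound is needed. Going by the values given here, compound 2 `CCC(C)CNCCN(C(=O)[C@@H]1C[C@H]1c1ccccc1)c1ccc(-c2ccccc2)cc1` gives 4.7 nM, so that a 2.3-fold lower number from compound 1 to compound 2 (0.37 log units; beyond the scatter) is the only measured step, and it concerns the amine-bearing chain, not the cyclopropane substituent. Compound 3 `CC[C@H](C)[C@H](N)CN(C(=O)[C@@H]1C[C@H]1c1ccc(C#N)cc1)c1ccc(-c2ccccc2)cc1` returns only a limit, > 25000 nM, in this assay. Compound 3 thus stands at the limit, (the limit of > 25000 nM in this assay, at which 1 of the 3 values shown sits), while compound 1 and compound 2 both carry a plain phenyl on the cyclopropane and sit far below it.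

Compound 4 `CC[C@H](C)[C@H](N)CN(C(=O)[C@@H]1C[C@H]1c1csc(C)n1)c1ccc(-c2ccccc2)cc1` changes the cyclopropane substituent of compound 3: 2-methyl-1,3-thiazol-4-yl in place of 4-cyanophenyl on a saturated ring carbon. Among the compounds with values here, no measured step touches this position, so the expectation rests only on the spread between the three values shown. Moving away from the 4-cyanophenyl of compound 3 may recover some activity, but whether a 2-methyl-1,3-thiazol-4-yl does so is not known from the data. Compound 4 is therefore expected to give about 5000 nM, within 300 nM to 25000 nM, in this assay, with a fair chance of another limit. This expectation corresponds to an at least 5.0-fold lower number from compound 3 to compound 4 (0.69 log units; beyond the scatter).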

Compound 4, half-maximal effective concentration: 1500 nM
Beside the measured number, compound 4's estimate is 3.3-fold (0.52 log units) above it, within the range that was stated.
By their numbers in this assay, from the lowest: compound 2; then compound 1; then compound 4. At a limit, above all of these: compound 3.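

The cyclopropane substituent now has a measured step in this assay: 2-methyl-1,3-thiazol-4-yl in place of 4-cyanophenyl gives an at least 16-fold lower number from compound 3 to compound 4 (1.22 log units; beyond the scatter). On the amine-bearing chain shared by these two compounds, this position can therefore carry a group with measurable agonist activity, as compound 4 gives 1500 nM. The size of the step is only a lower bound, because compound 3 stands at a limit of the assay: the limit of > 25000 nM in this assay, at which 1 of the 4 values shown sits.

The change replaces the nitrile and the six-membered aromatic ring together, and these compounds cannot separate the two. From the compounds shown here alone, how a plain phenyl behaves with the amine-bearing chain of compound 4 remains open, as does the effect of a pyridin-3-yl or a 1,3-thiazol-4-yl without the methyl on this saturated ring carbon.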